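This account rests on a few compounds, and the source may have more. Where it says the series, first, only, none or still open, it means among the compounds named here.

Measured so far in an ADME assay on HepG2 cells (Homo sapiens) for cytotoxicity, read by luminescence, CellTiter-Glo and ATP content, with a stated time of 72 h; a lower number here means that less compound is needed, a higher number that more compound is needed for the effect:
compound 1 `c1ccc(CCc2ccc3c(NCCCNCc4ccco4)ccnc3c2)cc1` gives 16000 nM
compound 2 `c1ccc(-c2ccc3c(NCCCNCc4ccco4)ccnc3c2)cc1` gives 5920 nM
compound 3 `COc1ccc(F)cc1CNCCCNc1ccnc2cc(CCc3ccccc3)ccc12` gives 4240 nM

Compound 4 `COc1ccc(F)cc1CNCCCNc1ccnc2cc(-c3ccccc3)ccc12` has not been measured. It differs from compound 3 by phenyl in place of phenethyl on an aromatic carbon. The same change has already been made once in this series, as phenyl in place of phenethyl on an aromatic carbon, where it gave a 2.7-fold lower number from compound 1 to compound 2 (0.43 log units; beyond the scatter). The place of the change is described in the same words in both pairs, so it is taken as the same change rather than merely the same kind. The two cores on which it is made are not identical: compound 3 differs from compound 1 by 5-fluoro-2-methoxyphenyl in place of furan-2-yl on a saturated chain carbon bound to an amine nitrogen, and that change on its own gave a 3.8-fold lower number from compound 1 to compound 3 (0.58 log units; beyond the scatter). The values of compound 2 and compound 3 lie within the scatter of each other, so nothing is read from their gap.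

Within the data shown here, with only one earlier instance of the change, the expected step is a 2.7-fold lower number from compound 3 to compound 4 (0.42 log units; beyond the scatter), resting on the single precedent a 2.7-fold lower number from compound 1 to compound 2 (0.43 log units; beyond the scatter) and on the assumption that the altered core does not reverse it. For compound 4 the estimate in this assay is 1600 nM, with a range from 700 nM to 3600 nM.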

Compound 4, half-maximal effective concentration: 2960 nM
For compound 4 the middle estimate is 1.9-fold (0.27 log units) below the measured one; measured number inside the range.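

In this assay, phenyl in place of phenethyl on the core carrying 5-fluoro-2-methoxyphenyl gives a 1.4-fold lower number from compound 3 to compound 4 (0.16 log units; within the scatter), and 5-fluoro-2-methoxyphenyl in place of furan-2-yl on the core carrying phenyl gives a 2.0-fold lower number from compound 2 to compound 4 (0.30 log units; within the scatter), so neither step stands clear of the scatter on its own. The phenyl change shows no difference between the two cores that can be told from scatter, although its step beyond the scatter on the first core is not reproduced as such on the second: the same change on two cores in this assay, a 2.7-fold lower number (0.43 log units; beyond the scatter) from compound 1 to compound 2 and a 1.4-fold lower number (0.16 log units; within the scatter) from compound 3 to compound 4, 1.9-fold (0.28 log units) apart, within the scatter of two such steps The same holds for the change of the aromatic group on the amine side chain, but this reading rests on the same compounds and is no independent support, and it does not prove that either change carries over unaltered to other cores: the same change on two cores in this assay, a 3.8-fold lower number (0.58 log units; beyond the scatter) from compound 1 to compound 3 and a 2.0-fold lower number (0.30 log units; within the scatter) from compound 2 to compound 4, 1.9-fold (0.28 log units) apart, within the scatter of two such steps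

Still open, as far as these compounds go, is whether these steps hold with a benzyl or phenoxy group on that aromatic carbon, or with a thiophene or pyridine ring in place of furan-2-yl. A longer chain joining the two amine nitrogens also remains to be set against these steps.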